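This account rests on a few compounds, and the source may have more. Where it says the series, first, only, none or still open, it means among the compounds named here.

Of the compounds shown here, two that share one core have been measured in an assay on HT-29 cells for inhibition of Serine-protein kinase ATM (Homo sapiens), read by fluorescence, with a stated time of 1 h; a lower number here means a stronger inhibitor, a higher number a weaker inhibitor. Compound 1 `C[C@@H](Nc1c(C(N)=O)cnc2ccc(-c3cccnc3)cc12)c1ccc(Cl)cc1` gives 109 nM in this assay. Compound 2 `CCC(CC)CNc1c(C(N)=O)cnc2ccc(-c3ccncc3)cc12` gives 418 nM in this assay, the higher of the two numbers; the gap to compound 1 lies beyond the usual scatter, but the two compounds differ in more than one place, so no single change can be read from it. The next compound, compound 3 `CCC(CC)CNc1c(C(N)=O)cnc2ccc(-c3ccc(CO)nc3)cc12`, carries 6-(hydroxymethyl)pyridin-3-yl in place of pyridin-4-yl on an aromatic carbon. Within the data shown here, no measured pair shows this change on its own, so its effect cannot be sized from data. Because compound 1 reaches 109 nM with a related ring at the same place on the core, a modest move toward a lower number is expected, though with little certainty. The expected shift is a 2.1-fold lower number from compound 2 to compound 3 (0.32 log units; beyond the scatter). For compound 3 the estimate is 200 nM, with a plausible range from 60 nM to 700 nM.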

Compound 3, half-maximal inhibitory concentration: 87 nM
Compound 3: middle estimate off by 2.3-fold (0.36 log units), on the high side; the measured number falls inside the stated range.
By their numbers in this assay, from the lowest: compounds 3 and 1 (each within the scatter of the next); then compound 2.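

In this assay, putting 6-(hydroxymethyl)pyridin-3-yl in place of pyridin-4-yl on the aromatic carbon gives a 4.8-fold lower number from compound 2 to compound 3 (0.68 log units; beyond the scatter). Among these compounds, this is the first change at this position that can be read on its own, and it shows that the number responds to the ring carried here, even with the rest of compound 2 left as it is. No measurement shown accounts for the size or direction of this step.

The step combines two differences, a new point of attachment on the pyridine ring and an added hydroxymethyl, so their shares cannot be separated. Also open, going by these compounds, is how a plain pyridin-3-yl ring, or one carrying a methoxymethyl or an aminomethyl in place of the hydroxymethyl, would compare on the rest of compound 2.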